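Heteroaryl swaps on the benzhydryl sulfoxide series

The source may report more compounds than this note shows. Statements on the series, on what has been measured and on what is new or still open speak of the compounds shown alone.

Two sulfoxides have been measured in an assay on HEK293 cells for inhibition of sodium-dependent dopamine transporter (Homo sapiens), read by scintillation counting, with stated times of 5 min and 1 min; a lower number here means a stronger inhibitor, a higher number a weaker inhibitor. Compound 1 `COC1NN=C(C[S+]([O-])C(c2ccccc2)c2ccccc2)S1` gives 108000 nM. For the measured compounds named here, compound 2 `[O-][S+](Cc1cc(C2CC2)on1)C(c1ccccc1)c1ccccc1` gives 38600 nM and thus holds the lowest of the two numbers; the only measured step leading to it, a 2.8-fold lower number from compound 1 to compound 2 (0.45 log units; beyond the scatter), is modest but beyond the scatter.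

Compound 3 `[O-][S+](Cc1ccncc1)C(c1ccccc1)c1ccccc1` is not yet measured. It differs from compound 2 by pyridin-4-yl in place of 5-cyclopropyl-1,2-oxazol-3-yl on a saturated chain carbon bound to a sulfur. Going by the values given here, the single measured step that bears on this position is the one from compound 1 to compound 2, which concerns the same place and the same kind of exchange of a small heteroaryl group, and it moved the number by a modest amount. Among the compounds with values here, no step involves a six-membered ring at this place, so the direction of the present change is not anchored by data. The expectation is therefore a step of about the same size as the one already seen, with no firm direction, and compound 3 is estimated at 50000 nM in this assay, within 15000 nM to 160000 nM, which corresponds to an expected step of a 1.3-fold higher number from compound 2 to compound 3 (0.11 log units; within the scatter).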

Compound 3, half-maximal inhibitory concentration: 63500 nM
Compound 3: middle estimate off by 1.3-fold (0.10 log units), on the low side, within the range that was stated.
By their numbers in this assay, from the lowest: compounds 2, 3 and 1 (each within the scatter of the next, the first and the last beyond it).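

In this assay, pyridin-4-yl brings the first six-membered aromatic ring to this place, on a saturated chain carbon bound to a sulfur, and the exchange for 5-cyclopropyl-1,2-oxazol-3-yl gives a 1.6-fold higher number from compound 2 to compound 3 (0.22 log units; within the scatter) while the exchange for the non-aromatic ring of compound 1 gives a 1.7-fold lower number from compound 1 to compound 3 (0.23 log units; within the scatter) and both steps stay within the scatter. Compound 3 therefore cannot be separated from either neighbour, although the earlier step still reads as a 2.8-fold lower number from compound 1 to compound 2 (0.45 log units; beyond the scatter) and stays beyond the scatter, so a six-membered aromatic ring carrying fewer heavy atoms and no cyclopropyl group does not resolve from either five-membered group in this set. No measurement at hand accounts for these readings.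

For the compounds shown here, with only three groups at this place, the series does not show whether the cyclopropyl group itself contributes to the reading of compound 2, which a 5-methyl-1,2-oxazol-3-yl or an unsubstituted 1,2-oxazol-3-yl group would test directly. Also open, as far as these compounds go, is how the number responds to a primary amine or a carboxylic acid on the pyridin-4-yl ring, or to a longer chain between that ring and the sulfur.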